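This account rests on a few compounds, and the source may have more. Where it says the series, first, only, none or still open, it means among the compounds named here.

Measured in a functional assay on LOX IMVI cells (Homo sapiens) for inhibition, read by sulforhodamine B assay, with a stated time of 48 h; on this read-out higher numbers stand for weaker inhibition of growth and lower numbers for stronger inhibition of growth:
compound 1 `CCOC(=O)[C@H](CCC(=O)O)NC(=O)c1ccc(CNc2nc3cc(N)cc(N)c3nc2-c2ccccc2)cc1`: < 100000 nM, a limit of the assay rather than a number.
compound 2 `COc1ccc(CNc2nc3cc(N)cc(N)c3nc2-c2ccccc2)cc1OC`: 14100 nM.
compound 3 `COc1cc(CNc2nc3cc(N)cc(N)c3nc2-c2ccccc2)cc(OC)c1OC`: 10500 nM.

Compound 2 gives the higher of the two numbers, with compound 3 nearest: a 1.3-fold lower number from compound 2 to compound 3 (0.13 log units; within the scatter). Compound 4 `COc1ccc(CNc2nc3cc(N)cc(N)c3nc2-c2ccccc2)cc1` is still to be measured in this assay. It differs from compound 2 by hydrogen in place of methoxy on an aromatic carbon; cut one bond further out, 3,4-dimethoxyphenyl becomes 4-methoxyphenyl. For the measured compounds named here, the only measured step bearing on this change is the reverse one, methoxy in place of hydrogen, a 1.3-fold lower number from compound 2 to compound 3 (0.13 log units; within the scatter), which stayed within the scatter. Removing a methoxy is therefore expected to give no step beyond the scatter in this assay, in either direction. Compound 4 is estimated at 14000 nM, between 6000 nM and 35000 nM, which amounts to an expected 1.0-fold lower number from compound 2 to compound 4 (0.00 log units; within the scatter).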

Compound 4, concentration for total growth inhibition: 27500 nM
The estimate for compound 4 lay 2.0-fold (0.29 log units) below the measured number; low and high end bracket the measured number.
By their numbers in this assay, from the lowest: compounds 3, 2 and 4 (each within the scatter of the next, the first and the last beyond it).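

In this assay, for the compounds shown here, going from 3,4-dimethoxyphenyl to 4-methoxyphenyl gives the first direct reading of methoxy removal on this aromatic carbon, ortho to a methoxy group: a 2.0-fold higher number from compound 2 to compound 4 (0.29 log units; within the scatter). Hydrogen and methoxy at this position therefore stay within the scatter of each other, so the position shows no step beyond it so far. Nothing at hand gives a reason for this step.

Open, from the compounds shown here alone, is whether an amine, a hydroxyl or a carboxylic acid at this position would read differently. Also open, going by these compounds, is what happens when the remaining methoxy gives way to hydrogen.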